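The source may report more compounds than this note shows. Statements on the series, on what has been measured and on what is new or still open speak of the compounds shown alone.

Measured so far in a functional assay on MCF7 cells (Homo sapiens) for cytotoxicity, read by CCK-8 assay, with a stated time of 72 h; on this read-out lower numbers stand for stronger inhibition and higher numbers for weaker inhibition:
- compound 1 `C=CCn1c(=O)/c(=C\c2cc(Br)ccc2F)[nH]c(=O)/c1=C\c1ccccc1OC`: 28100 nM
- compound 3 `C=CCn1c(=O)/c(=C\c2cccc(C)c2)[nH]c(=O)/c1=C\c1ccccc1OC`: 20700 nM
- compound 2 `C=CCn1c(=O)/c(=C\c2ccc(F)c(Br)c2)[nH]c(=O)/c1=C\c1ccccc1OC`: reported as "not active" (no number reported), with no number given.

Compound 3 has the lowest of the two numbers available in this assay. Its nearest neighbour is compound 1, and the step of a 1.4-fold lower number from compound 1 to compound 3 (0.13 log units; within the scatter) stays within the usual scatter, so the two compounds cannot be told apart on these data. For compound 2 only the verdict of no activity is available, without a number.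

Compound 4 `C=CCn1c(=O)/c(=C\c2ccccc2F)[nH]c(=O)/c1=C\c1ccccc1OC` is not yet measured. It differs from compound 3 in one place: 2-fluorophenyl in place of 3-methylphenyl on a double-bonded chain carbon bound to an aromatic carbon. For the measured compounds named here, the only measured step that bears on this position is a 1.4-fold lower number from compound 1 to compound 3 (0.13 log units; within the scatter), and it was within the scatter. That single step is the whole basis for an expectation, and it points to no clear movement when the group on this carbon is exchanged. The step of a 1.2-fold higher number from compound 3 to compound 4 (0.08 log units; within the scatter) is therefore expected to stay small. Compound 4 is estimated at 25000 nM, with a range from 8000 nM to 80000 nM.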

Compound 4, half-maximal inhibitory concentration: 23000 nM
The estimate for compound 4 lay 1.1-fold (0.04 log units) above the measured number; the measured number falls inside the stated range.
By their numbers in this assay, from the lowest: compounds 3, 4 and 1 (each within the scatter of the next).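

In this assay, 2-fluorophenyl in place of 3-methylphenyl on this carbon gives a 1.1-fold higher number from compound 3 to compound 4 (0.05 log units; within the scatter), so a methyl-bearing ring and a fluorine-bearing ring cannot be told apart here. For the compounds shown here, compound 4 also isolates a second change that the earlier compounds did not: hydrogen in place of bromo on an aromatic carbon gives a 1.2-fold lower number from compound 1 to compound 4 (0.09 log units; within the scatter), so these data show no need for the bromo group in this assay. No measurement is available to explain why these exchanges leave the read-out within the scatter.

All the numbered results so far come from phenyl rings carrying only halogen or methyl groups on this carbon. As far as these compounds go, whether a ring bearing an amine or a carboxylic acid would give a step beyond the scatter remains open.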